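Compound 3 to compound 4: cyano in place of methoxy

The compounds below may be only part of what the source reports. "The series", "measured", "known", "first", "only" and "open" are said of these compounds alone.

In a functional assay on MKN-45 cells (Homo sapiens) for cytotoxicity (a lower number here means a stronger inhibitor, a higher number a weaker inhibitor), compound 3 (`COc1ccc(C(=O)Nc2cccc3c2N(S(=O)(=O)c2ccc(OC)cc2)CC3)cc1`) reads 1600 nM and compound 1 (`COc1ccc(S(=O)(=O)N2CCc3cccc(NS(=O)(=O)c4ccc(F)cc4)c32)cc1`) reads 890 nM, with a 1.8-fold higher number from compound 1 to compound 3 (0.25 log units; within the scatter) separating them. Going by the values given here, these two sit together at the high end of the numbers so far, while compound 2 (`COc1ccc(S(=O)(=O)N2CCc3cccc(NC(=O)c4ccncc4)c32)cc1`) gives 8.8 nM and stands well apart.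

Compound 4 (`COc1ccc(S(=O)(=O)N2CCc3cccc(NC(=O)c4ccc(C#N)cc4)c32)cc1`) has cyano in place of methoxy on an aromatic carbon, para to a large group (cyano in place of methoxy on an aromatic carbon). The closest evidence is a 180-fold higher number from compound 2 to compound 3 (2.26 log units; beyond the scatter) on exchanging pyridin-4-yl for 4-methoxyphenyl on the same carbonyl carbon. The change from the sulfonyl group, a 100-fold lower number from compound 1 to compound 2 (2.00 log units; beyond the scatter) for the pyridine amide, points the same way. Only these two amides show that this end of the molecule can move the number strongly, and no 4-cyanophenyl amide has been measured. Part of that large gap is therefore expected to be recovered, towards a lower number.

In this assay the expected change is a 6.4-fold lower number from compound 3 to compound 4 (0.81 log units; beyond the scatter) with wide uncertainty. For compound 4 the estimate is 250 nM with an expected range of 30 nM to 2000 nM in this measurement.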

Compound 4, half-maximal inhibitory concentration: 89 nM
Estimate against measurement, compound 4: 2.8-fold (0.45 log units) above; low and high end bracket the measured number.
By their numbers in this assay, from the lowest: compound 2; then compound 4; then compounds 1 and 3 (each within the scatter of the next).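

In this assay the amide end of the series responds to a single substituent, not only to the exchange of a whole ring: an 18-fold lower number from compound 3 to compound 4 (1.25 log units; beyond the scatter) for cyano in place of methoxy, para to a large group. The 4-cyanophenyl amide recovers only part of the gap to the pyridin-4-yl amide, as a 10-fold higher number from compound 2 to compound 4 (1.00 log units; beyond the scatter) remains, while a 10-fold lower number from compound 1 to compound 4 (1.00 log units; beyond the scatter) also sets it clearly apart from the sulfonyl compound. Nothing measured here bears on the cause of these steps.

As far as these compounds go, with only methoxy and cyano compared at this place, it remains open whether the response follows any order across substituents, and an amine or a carboxylic acid in place of cyano would test this. Also open, from the compounds shown here alone, is whether the other sulfonyl group of the shared core affects the size of these steps.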